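A few compounds are considered here, and "the series" means these few. Any claim that something is new, unique, unknown or untested is made for them only; others in the source may bear on it.

Measured so far in a functional assay on DU-145 cells (Homo sapiens) for inhibition, read by trypan blue exclusion, with a stated time of 96 h; a higher number here means a weaker inhibitor of growth, a lower number a stronger inhibitor of growth:
compound 1, `Cc1ccc(CS/C(=C/c2ccc(Cl)c([N+](=O)[O-])c2)C(=O)c2ccc(C(=O)O)cc2)cc1`: 1000 nM
compound 2, `Cc1ccc(CS/C(=C/c2cc(Cl)cc(Cl)c2)C(=O)c2ccc(Cl)cc2)cc1`: 10000 nM
compound 3, `Cc1ccc(S/C(=C/c2ccc(F)c(C)c2)C(=O)c2ccc(Br)cc2)cc1`: 25000 nM

Compound 2 stands second highest among the three numbers in this assay. Its nearest neighbour is compound 3, whose number is higher by a margin beyond the usual scatter; its furthest is compound 1, whose number is lower by a margin well beyond the scatter. The three measured compounds differ from one another in more than one place, so no single step between any two of them can be read from the data, and no cause for the spread is assigned.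

Compound 4, `Cc1ccc(CS/C(=C/c2cc(C)ccc2C)C(=O)c2ccc(Cl)cc2)cc1`, has not yet been measured in this assay. It differs from compound 2 in one place: 2,5-dimethylphenyl in place of 3,5-dichlorophenyl on a double-bonded chain carbon bound to a double-bonded chain carbon. The shared core and all other groups of compound 2 are kept. Going by the values given here, no measured pair isolates a change of this kind, so there is no direct precedent for its size or direction. A step of modest size is expected, leaning toward a somewhat higher number, and the step of a 1.3-fold higher number from compound 2 to compound 4 (0.11 log units; within the scatter) is estimated accordingly. On that basis compound 4 is expected to give about 13000 nM, with a range from 4000 nM to 40000 nM.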

Compound 4, concentration for 50% growth inhibition: 10000 nM
For compound 4 the middle estimate is 1.3-fold (0.11 log units) above the measured one; the range from low to high includes it.
By their numbers in this assay, from the lowest: compound 1; then compounds 2 and 4 (each within the scatter of the next); then compound 3.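

In this assay, going by these compounds alone, the one pair that differs in a single place gives no change at the digits printed from compound 2 to compound 4 (within the scatter), the first reading of a change at this position, on a double-bonded chain carbon bound to a double-bonded chain carbon. Here 2,5-dimethylphenyl replaces 3,5-dichlorophenyl with the same heavy-atom count and the same aromatic ring of carbon only, so for this pair the chlorine atoms are not needed to keep the number at this level. No measured property bears on this result, and the data offer no explanation for it.

A single pair cannot show whether this position accepts other groups as readily, for instance a phenyl ring carrying a carboxylic acid, an amine or a methoxy group, or whether a larger step would then appear. All other pairs differ in more than one place, so their steps cannot be read, and the parts of the structure that account for the spread across compounds 1, 3 and this pair remain unassigned.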